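Thiophen-2-yl on the sulfonyl sulfur: working notes

This account rests on a few compounds, and the source may have more. Where it says the series, first, only, none or still open, it means among the compounds named here.

Measured values in a functional assay on HL-60 cells (Homo sapiens) for inhibition, read by CCK-8 assay, with a stated time of 48 h, tested at 20 uM (a higher number here means more inhibition of growth at the concentration tested, a lower number less inhibition of growth), are these:
compound 1 `COc1ccc(-c2nnc(NC(=O)/C(C#N)=C/c3cccc(OS(=O)(=O)c4ccc(C)cc4)c3)s2)cc1` gives 73%
compound 2 `Cc1ccc(S(=O)(=O)Oc2cccc(/C=C(\C#N)C(=O)Nc3nnc(-c4cccs4)s3)c2)cc1` gives 62%
compound 3 `CC(=O)Nc1ccc(S(=O)(=O)Oc2cccc(/C=C(\C#N)C(=O)Nc3nnc(-c4cccs4)s3)c2)cc1` gives 71%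

Compound 3 at 71% lies within the scatter of both other compounds, so no order can be drawn around it. Only compound 1 and compound 2 stand apart from each other. Next is compound 4 `N#C/C(=C\c1cccc(OS(=O)(=O)c2cccs2)c1)C(=O)Nc1nnc(-c2cccs2)s1` with the change thiophen-2-yl in place of 4-acetamidophenyl on a sulfonyl sulfur and thus thiophen-2-yl in place of 4-acetamidophenyl on a sulfonyl sulfur.

For the measured compounds named here, two measured steps bear on this. The group on the same sulfonyl sulfur varies with acetamido in place of methyl on an aromatic carbon, which gives a number 9 percentage points higher from compound 2 to compound 3 (within the scatter) and so nothing beyond the scatter. Thiophen-2-yl also enters elsewhere, in place of 4-methoxyphenyl on an aromatic carbon, which gives a number 11 percentage points lower from compound 1 to compound 2 (beyond the scatter) as a modest step beyond the scatter. Neither step is the same exchange as the one in question, so they bound its size only loosely. In this assay a small step to the lower side is expected, none beyond the scatter. The expected change is a number 6 percentage points lower from compound 3 to compound 4 (within the scatter) on this evidence. For compound 4 the estimate is 65% with an expected range of 52% to 76% in this read-out.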

Compound 4, percent growth inhibition at one concentration: 30%
Beside the measured number, compound 4's estimate is 35 percentage points above it; measured number below the stated range.
By their numbers in this assay, from the lowest: compound 4; then compounds 2, 3 and 1 (each within the scatter of the next, the first and the last beyond it).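

Under this assay thiophen-2-yl on the sulfonyl sulfur gives a number 41 percentage points lower from compound 3 to compound 4 (beyond the scatter) in place of 4-acetamidophenyl and a number 32 percentage points lower from compound 2 to compound 4 (beyond the scatter) in place of 4-methylphenyl, so the sulfonyl sulfur position is not as undemanding as the earlier compounds suggested. For the compounds shown here, the only earlier change in this group, a number 9 percentage points higher from compound 2 to compound 3 (within the scatter) for acetamido in place of methyl, altered a substituent and kept the six-membered aromatic ring, while exchanging the ring itself for the five-membered one produces the largest steps, and at both starting points. The same thiophen-2-yl placed on the aromatic carbon at the other end of the molecule gave only a number 11 percentage points lower from compound 1 to compound 2 (beyond the scatter) as a modest step, so the size of its effect depends on where it stands, and no measurement shown gives a reason for the drop at the sulfonyl sulfur.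

The compounds shown do not separate the loss of the six-membered ring from the loss of the group it carries, a question that unsubstituted phenyl or pyridin-3-yl on the sulfonyl sulfur would address. Also open, from the compounds shown here alone, is whether thiophen-2-yl on the sulfonyl sulfur costs as much when 4-methoxyphenyl stands at the other end of the molecule.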